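The compounds below may be only part of what the source reports. "The series", "measured", "known", "first", "only" and "open" are said of these compounds alone.

Series notes. Compound 1 `Cc1ccc(-c2cn(C/C=C3\OC(=O)C(OCc4ccccc4)=C3OCc3ccccc3)nn2)cc1` and compound 2 `O=C1O[C@H]([C@@H](O)Cn2cc(-c3cccc(O)c3)nn2)C(OCc2ccccc2)=C1OCc1ccccc1` share the core; compound 3 `CCCCCc1ccc(-c2cn(C/C=C3\OC(=O)C(OCc4ccccc4)=C3OCc3ccccc3)nn2)cc1` is the pentyl homologue of compound 1. In a functional assay on SW-620 cells (Homo sapiens) for antiproliferative activity, read by MTT assay, with a stated time of 72 h (on this read-out higher numbers stand for weaker inhibition and lower numbers for stronger inhibition), compound 1 gives > 100000 nM, which is a limit of the assay and not a number. In this assay compound 2 gives > 100000 nM, again a limit and not a number. Among the measured compounds shown here, compound 1 therefore stands only at the limit of > 100000 nM in this assay, at which 2 of the 2 values shown sit; no order among the measured compounds can be read, and no step between them can be counted. The change to compound 3 is butyl in place of hydrogen on a saturated chain carbon bound to an aromatic carbon. For the measured compounds named here, with both measured compounds sitting at the limit there is no measured step to lean on. The step from compound 1 to compound 3 is expected to be a number no higher from compound 1 to compound 3 (the limit leaves the size open), that is none beyond the scatter, with its direction unknown. Compound 3 is estimated at 100000 nM in this assay, with a range from 30000 nM to 300000 nM, and most likely a limit is reported again.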

Compound 3, half-maximal inhibitory concentration: > 100000 nM
Compound 3 was reported as a limit; the forecaster's own chance of this, stated with the estimate: 75%; the middle value lies on the limit itself.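

No new step can be read from compound 1 to compound 3 in this assay, because both values are limits of the assay and not numbers: the limit of > 100000 nM in this assay, at which 3 of the 3 values shown sit.

The compounds shown leave open whether methyl to pentyl, or any other change on the shared core, shifts the read-out at all.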